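Swapping trifluoromethyl for hydroxy on a weak inhibitor

A few compounds are considered here, and "the series" means these few. Any claim that something is new, unique, unknown or untested is made for them only; others in the source may bear on it.

Within the data shown here, compound 2 `COc1cc(/C=C/c2nc(Nc3ccc(C(F)(F)F)cc3)c3sccc3n2)cc(OC)c1OC` is the only compound with an actual number in a functional assay on L02 cells (Homo sapiens) for inhibition, read by Griess assay, with stated times of 1 h and 24 h; on this read-out higher numbers stand for weaker inhibition and lower numbers for stronger inhibition; in this assay compound 2 gives 436000 nM. Compound 1 `COc1cc(/C=C/c2nc(NC3CC3)c3sccc3n2)cc(OC)c1OC` reaches only a limit. In this assay compound 1 gives > 1000000 nM, which is a limit of the assay and not a number. Among the measured compounds shown here, the single measured step, an at least 2.2-fold lower number from compound 1 to compound 2 (0.36 log units; beyond the scatter), is anchored by the limit of > 1000000 nM in this assay, at which 1 of the 2 values shown sits. Compound 3 `COc1cc(/C=C/c2nc(Nc3ccc(O)cc3)c3sccc3n2)cc(OC)c1OC` differs from compound 2 by hydroxy in place of trifluoromethyl on an aromatic carbon. For the measured compounds named here, no measured step touches this position on the ring, so the one known step offers no direct guide and only shows that changing the group on that nitrogen moves the number modestly. A step no larger than the usual scatter is therefore expected, a 1.1-fold higher number from compound 2 to compound 3 (0.06 log units; within the scatter), with no set direction. For compound 3 the estimate in this assay is 500000 nM, within a range from 150000 nM to 1500000 nM.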

Compound 3, half-maximal inhibitory concentration: > 1000000 nM
Compound 3: no number, only a limit; the forecaster's own chance of this, stated with the estimate: 30%; at least 2.0-fold (0.30 log units) between middle value and limit.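

Hydroxy in place of trifluoromethyl gives an at least 2.2-fold higher number from compound 2 to compound 3 (0.36 log units; beyond the scatter), so the group on this aromatic carbon, para to a large group, does affect the read-out. A phenyl ring on the nitrogen is therefore not enough on its own to give a measurable number: in this assay compound 3 gives > 1000000 nM, which is a limit of the assay and not a number. The true size of this step remains unknown, and only its minimum can be stated: the limit of > 1000000 nM in this assay, at which 2 of the 3 values shown sit.

Going by these compounds, compound 1 and compound 3 both end at limits, so the step between them cannot be read and their order stays open. Also open, on these data alone, is how an amine, a carboxylic acid or a methoxy group on this same aromatic carbon would compare with trifluoromethyl and hydroxy.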